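Compound 3 to Compound 4: A Swap on the Aromatic Nitrogen

A few compounds are considered here, and "the series" means these few. Any claim that something is new, unique, unknown or untested is made for them only; others in the source may bear on it.

Measured so far in a functional assay on HCT-116 cells (Homo sapiens) for inhibition, read by MTT assay, with a stated time of 72 h; on this read-out lower numbers stand for stronger inhibition of growth and higher numbers for weaker inhibition of growth:
compound 1 `CC1=C(CCCCCCCCCCn2cc(C[C@H](O)COCCOC[C@@H](O)Cc3ccc(-c4ccccc4)cc3)nn2)C(=O)c2ccccc2C1=O`: 3000 nM
compound 2 `O[C@H](COCCOC[C@@H](O)Cc1cn(Cc2ccc(Oc3ccccc3)cc2)nn1)Cc1ccc(-c2ccccc2)cc1`: 3400 nM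
compound 3 `O[C@H](COCCOC[C@@H](O)Cc1cn(-c2cccs2)nn1)Cc1ccc(-c2ccccc2)cc1`: 33400 nM

Compound 3 stands highest of the three numbers in this assay, beyond the scatter from compound 2, its nearest, and further still from compound 1. Compound 4 `O[C@H](COCCOC[C@@H](O)Cc1cn(-c2ccc3[nH]ccc3c2)nn1)Cc1ccc(-c2ccccc2)cc1` keeps the shared core and differs from compound 3 in one place: 1H-indol-5-yl in place of thiophen-2-yl on an aromatic nitrogen. Within the data shown here, no measured pair shows this change, so its size is not known. Since compound 1 gives 3000 nM and compound 2 gives 3400 nM with larger groups on that nitrogen, a moderate fall beyond the scatter is expected for compound 4. Compound 4 is estimated at 12000 nM, with a range of 4000 nM to 35000 nM. This expectation means a step of a 2.8-fold lower number from compound 3 to compound 4 (0.44 log units; beyond the scatter).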

Compound 4, concentration for 50% growth inhibition: 15500 nM
Compound 4: middle estimate off by 1.3-fold (0.11 log units), on the low side, and the stated range covers the measured number.
By their numbers in this assay, from the lowest: compounds 1 and 2 (each within the scatter of the next); then compound 4; then compound 3.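

In this assay the aromatic nitrogen now has its first single-place comparison: 1H-indol-5-yl in place of thiophen-2-yl gives a 2.2-fold lower number from compound 3 to compound 4 (0.33 log units; beyond the scatter) and so a modest change at this position. The entering group adds heavy atoms, a six-membered aromatic ring and a hydrogen-bond donor, and this one step cannot separate these differences. No measured evidence bears on what lies behind the step.

Left open is how a plain phenyl group or a carboxylic acid on this nitrogen would compare, and whether the hydrogen-bond donor of 1H-indol-5-yl plays any part.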